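The source may report more compounds than this note shows. Statements on the series, on what has been measured and on what is new or still open speak of the compounds shown alone.

Measured compounds in a functional assay on DU-145 cells (Homo sapiens) for inhibition; a lower number here means a stronger inhibitor, a higher number a weaker inhibitor:
compound 1, `Oc1cccc(-c2cc(-c3ccccc3F)cc(-c3cccc(O)c3)n2)c1`, compound 1 gives 11200 nM
compound 2, `Oc1cccc(-c2cc(-c3ccc(F)cc3)cc(-c3cccc(O)c3)n2)c1`, compound 2 gives 7120 nM
compound 3, `Oc1cccc(-c2cc(-c3ccccc3C(F)(F)F)cc(-c3cccc(O)c3)n2)c1`, compound 3 gives 2870 nM

Compound 3 holds the lowest number of the three. Both a 3.9-fold lower number from compound 1 to compound 3 (0.59 log units; beyond the scatter) and a 2.5-fold lower number from compound 2 to compound 3 (0.39 log units; beyond the scatter) lie beyond the scatter, so within this set compound 3 is the strongest inhibitor, with compound 2 nearest and compound 1 furthest.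

Compound 4, `Oc1cccc(-c2cc(-c3ccc(C(F)(F)F)cc3)cc(-c3cccc(O)c3)n2)c1`, has not yet been measured. The change from compound 3 is 4-(trifluoromethyl)phenyl in place of 2-(trifluoromethyl)phenyl on an aromatic carbon. The group sits on an aromatic carbon of the six-membered aromatic ring with one nitrogen, meta to two 3-hydroxyphenyl groups, opposite the ring nitrogen.

For the measured compounds named here, one measured step bears directly on this change: a 1.6-fold lower number from compound 1 to compound 2 (0.20 log units; within the scatter), the same relocation of a substituent within the phenyl, and it stayed within the scatter. The steps of a 3.9-fold lower number from compound 1 to compound 3 (0.59 log units; beyond the scatter) and a 2.5-fold lower number from compound 2 to compound 3 (0.39 log units; beyond the scatter) concern the trifluoromethyl itself, which compound 4 retains. No step beyond the scatter is therefore expected in this assay for compound 4, with at most a small lowering of the number. Compound 4 is expected to give 2400 nM, with a range of 1000 nM to 6000 nM, an expected step of a 1.2-fold lower number from compound 3 to compound 4 (0.08 log units; within the scatter).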

Compound 4, half-maximal inhibitory concentration: 33500 nM
Beside the measured number, compound 4's estimate is 14-fold (1.14 log units) below it, and the stated range ends below it.
By their numbers in this assay, from the lowest: compound 3; then compounds 2 and 1 (each within the scatter of the next); then compound 4.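

In this assay, the location of the trifluoromethyl on the phenyl matters: a 12-fold higher number from compound 3 to compound 4 (1.07 log units; beyond the scatter), whereas the corresponding relocation of fluoro gave a 1.6-fold lower number from compound 1 to compound 2 (0.20 log units; within the scatter), within the scatter. The other two new steps, a 4.7-fold higher number from compound 2 to compound 4 (0.67 log units; beyond the scatter) and a 3.0-fold higher number from compound 1 to compound 4 (0.48 log units; beyond the scatter), make 4-(trifluoromethyl)phenyl the weakest of the four groups shown at this position, so trifluoromethyl does not lower the number wherever it stands on the phenyl. Fluoro to trifluoromethyl therefore has no single direction in this series, and its outcome reverses between the 2-substituted and 4-substituted phenyl pairs: the same change on two cores in this assay, a 3.9-fold lower number (0.59 log units; beyond the scatter) from compound 1 to compound 3 and a 4.7-fold higher number (0.67 log units; beyond the scatter) from compound 2 to compound 4, 18-fold (1.26 log units) apart, beyond the scatter of two such steps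

The compounds shown do not tell what underlies this reversal, nor whether it is particular to trifluoromethyl or would also appear with a methoxy or a nitrile on the phenyl. Also open, from the compounds shown here alone, is whether 2-(trifluoromethyl)phenyl would keep its advantage over 4-(trifluoromethyl)phenyl if an amine or a carboxylic acid replaced the hydroxyl on the two 3-hydroxyphenyl groups.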